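The compounds below may be only part of what the source reports. "The series", "measured", "known", "first", "only" and "open" are said of these compounds alone.

Measured so far in a functional assay on CHO cells for antagonist activity at prostaglandin E2 receptor EP3 subtype (Homo sapiens), read by cAMP accumulation; a higher number here means a weaker inhibitor, a lower number a stronger inhibitor:
compound 1, `Cc1nc(C(c2ccc(-c3ccc4cccc(F)c4c3)[nH]c2=O)C(C)C)[nH]c1C` — 50 nM
compound 2, `CC(C)C(c1ncc[nH]1)c1ccc(-c2ccc3cccc(F)c3c2)[nH]c1=O` — 33 nM

Within the data shown here, compound 2 and compound 1 lie within the scatter of each other; the only step recorded, a 1.5-fold lower number from compound 1 to compound 2 (0.18 log units; within the scatter), is too small to read as a change. Compound 3, `CC(C)NC(=O)CC(c1ccc(-c2ccc3cccc(F)c3c2)[nH]c1=O)C(C)C`, is not yet measured. It differs from compound 2 by (isopropylcarbamoyl)methyl in place of 1H-imidazol-2-yl on a saturated chain carbon bound to an aromatic carbon and a saturated chain carbon. Among the measured compounds shown here, no measured pair covers this exchange: the one known step concerns two substituents on the imidazole, not the loss of the five-membered ring for an open amide-bearing chain, so it gives no direct guide. The exchange is larger than any step seen here, and the expectation is therefore a wider uncertainty than the scatter alone, with a weaker number judged somewhat more likely than a stronger one. For compound 3 the estimate in this assay is 150 nM, range 40 nM to 600 nM, meaning an expected step of a 4.5-fold higher number from compound 2 to compound 3 (0.66 log units; beyond the scatter).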

Compound 3, half-maximal inhibitory concentration: 15 nM
Compound 3: middle estimate off by 10-fold (1.00 log units), on the high side; the whole stated range lies above it.
By their numbers in this assay, from the lowest: compound 3; then compounds 2 and 1 (each within the scatter of the next).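

In this assay this saturated chain carbon does not depend on an imidazole ring: the open (isopropylcarbamoyl)methyl chain, which has no ring, replaces 1H-imidazol-2-yl with a modest gain (a 2.2-fold lower number from compound 2 to compound 3 (0.34 log units; beyond the scatter)) and 4,5-dimethyl-1H-imidazol-2-yl with a similarly modest gain (a 3.3-fold lower number from compound 1 to compound 3 (0.52 log units; beyond the scatter)). The earlier pair changed only the substituents on the ring and stayed within the scatter, whereas this exchange of the whole ring for an amide-bearing chain moves the number beyond it. No available data explain the gain.

Only one open chain is shown, so it remains open whether the isopropyl group on the amide matters, as a primary amide or a tert-butyl amide would test. Also unresolved is whether a carboxylic acid, an amine or a longer chain at this place would hold the number.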